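The compounds below may be only part of what the source reports. "The series", "measured", "known", "first", "only" and "open" are said of these compounds alone.

Measured compounds:
- compound 1 `Cc1ccccc1Cc1cnc(CCc2ccc(-c3ccccc3C(=O)O)cc2)[nH]1`: 127 nM
- compound 2 `COc1ccc(Cc2cnc(CCc3ccc(-c4ccccc4C(=O)O)cc3)[nH]2)cc1`: 5360 nM
- compound 3 `O=C(O)c1ccccc1-c1ccc(CCc2ncc(Cc3ccccc3F)[nH]2)cc1`: 177 nM

In an in vitro functional assay on cells for agonist activity at Bombesin receptor subtype-3 (Homo sapiens), read by luminescence and calcium flux (on this read-out higher numbers stand for an effect only at larger amounts of compound and lower numbers for an effect already at smaller amounts), compound 3 stands at the second highest of the three numbers; compound 1 gives a number within the scatter of it, as a 1.4-fold higher number from compound 1 to compound 3 (0.14 log units; within the scatter) shows, while compound 2 lies far off, with a 30-fold lower number from compound 2 to compound 3 (1.48 log units; beyond the scatter). Compound 4 `O=C(O)c1ccccc1-c1ccc(CCc2ncc(CCc3ccccc3)[nH]2)cc1` differs from compound 3 by benzyl in place of 2-fluorophenyl on a saturated chain carbon bound to an aromatic carbon; read one bond further out, a 2-fluorobenzyl becomes a phenethyl. Among the compounds with values here, no measured step makes exactly this change. The steps that touch the same place show that exchanging methyl for fluoro on the aromatic carbon, a 1.4-fold higher number from compound 1 to compound 3 (0.14 log units; within the scatter), stays within the scatter, whereas moving to a 4-methoxyphenyl, a 42-fold higher number from compound 1 to compound 2 (1.63 log units; beyond the scatter), is a large loss. Compound 4 drops the fluorine and lengthens the chain, so some loss beyond the scatter is expected, though smaller than that of compound 2; compound 4 is expected to give 450 nM (range 120 nM to 2000 nM), a step of a 2.5-fold higher number from compound 3 to compound 4 (0.41 log units; beyond the scatter).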

Compound 4, half-maximal effective concentration: 1320 nM
Compound 4: the middle estimate sits 2.9-fold (0.47 log units) below what was measured; the range from low to high includes it.
By their numbers in this assay, from the lowest: compounds 1 and 3 (each within the scatter of the next); then compound 4; then compound 2.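

In this assay, within the data shown here, the earlier compounds had only changed what the ring carries, whereas compound 4 shows that this position also responds when 2-fluorobenzyl becomes phenethyl: a 7.5-fold higher number from compound 3 to compound 4 (0.87 log units; beyond the scatter), and a 10-fold higher number from compound 1 to compound 4 (1.02 log units; beyond the scatter). This change is nevertheless less damaging than the 4-methoxyphenyl group, as a 4.1-fold lower number from compound 2 to compound 4 (0.61 log units; beyond the scatter) shows, so among these compounds the phenethyl group falls in an intermediate place, above the pair with a small group on the ring and below compound 2. Nothing available explains the loss seen with compound 4.

Compound 4 loses the fluorine and lengthens the chain in one step, so the two changes cannot be told apart here. A plain benzyl group and a 2-fluorophenethyl group at this place would separate them.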